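The compounds below may be only part of what the source reports. "The series", "measured", "known", "first", "only" and "open" are said of these compounds alone.

Compound 3 `Cc1cn(Cc2ccc(O)c(C(C)(C)C)c2)c2ccc(OCC(=O)O)cc12` is the weakest-looking of the three measured compounds: in an assay on HeLa cells for displacement of a labelled ligand from thyroid hormone receptor alpha (Homo sapiens) (a lower number here means a stronger inhibitor, a higher number a weaker inhibitor), compound 3 gives 9.98 nM. That number is within the scatter of compound 1 `Cc1cn(Cc2ccc(O)c(C(C)C)c2)c2ccc(OCC(=O)O)cc12`, which in this assay gives 7.74 nM, while compound 2 `Cc1cn(Cc2ccc(O)c(C(C)C)c2)c2c(C)cc(OCC(=O)O)cc12` gives 2.77 nM. The gap between compound 3 and compound 2 is not covered by the scatter. Compound 4 `Cc1cn(Cc2ccc(O)c(C3CCCCC3)c2)c2ccc(OCC(=O)O)cc12` differs from compound 3 by cyclohexyl in place of tert-butyl on an aromatic carbon. Going by the values given here, the only measured step at this same position is a 1.3-fold higher number from compound 1 to compound 3 (0.11 log units; within the scatter), a change within the scatter; the other step, a 2.8-fold lower number from compound 1 to compound 2 (0.45 log units; beyond the scatter), concerns a different part of the shared core and says little here. Among the compounds with values here, the one relevant step being small, a step of about a 1.0-fold higher number from compound 3 to compound 4 (0.00 log units; within the scatter) is expected, with no clear direction. Compound 4 is therefore estimated at 10 nM, in the range 4 nM to 25 nM.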

Compound 4, inhibition constant: 200 nM
Estimate against measurement, compound 4: 20-fold (1.30 log units) below, and the stated range ends below it.
By their numbers in this assay, from the lowest: compound 2; then compounds 1 and 3 (each within the scatter of the next); then compound 4.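

The aromatic carbon ortho to a hydroxy group does not accept every carbon-only group equally: isopropyl and tert-butyl give values within the scatter of each other, but cyclohexyl gives a 20-fold higher number from compound 3 to compound 4 (1.30 log units; beyond the scatter) and a 26-fold higher number from compound 1 to compound 4 (1.41 log units; beyond the scatter) in this assay. Neither the leaving nor the entering group has hydrogen-bond donors or acceptors or a net charge, so the large step comes with a change in carbon groups alone. Nothing shown here explains why the number rises so sharply.

As far as these compounds go, whether the ring or the larger carbon count goes with the higher number stays open. A cyclopropyl ring or an open hexyl chain at this position would help separate the two.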